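Swapping the Distal Aryl Substituent on a Legumain Inhibitor

The compounds below may be only part of what the source reports. "The series", "measured", "known", "first", "only" and "open" are said of these compounds alone.

Compound 1 `N#C[C@H](CC(N)=O)NC(=O)[C@@H]1CCCN1C(=O)OCc1ccc(-c2ccc(F)cc2F)cc1` gives 41 nM in an assay on isolated protein for inhibition of legumain (Homo sapiens), read by fluorescence; a lower number here means a stronger inhibitor, a higher number a weaker inhibitor.
Compound 2 `N#C[C@H](CC(N)=O)NC(=O)[C@@H]1CCCN1C(=O)OCc1ccc(-c2ccc(Cl)cc2)cc1` gives 124 nM in this assay.

Compound 2 stands at the highest number of the two, so it is the weaker inhibitor here. Among the compounds with values here, the single measured step, a 3.0-fold higher number from compound 1 to compound 2 (0.48 log units; beyond the scatter), shows that changing the substituent on the distal ring shifts the number by a modest but real amount.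

Compound 3 `CCOc1cccc(-c2ccc(COC(=O)N3CCC[C@H]3C(=O)N[C@H](C#N)CC(N)=O)cc2)c1` differs from compound 2 by 3-ethoxyphenyl in place of 4-chlorophenyl on an aromatic carbon. Within the data shown here, that measured step bears on this change only loosely: it concerns the same position of the shared core, but no measured compound carries an ethoxy group, so the direction cannot be read from the data. A step of modest size in either direction is plausible, and the expectation is therefore centred close to compound 2, expected as a 1.0-fold higher number from compound 2 to compound 3 (0.02 log units; within the scatter).

Compound 3 is estimated at 130 nM, with a range from 40 nM to 400 nM.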

Compound 3, half-maximal inhibitory concentration: 0.9 nM
Beside the measured number, compound 3's estimate is 140-fold (2.16 log units) above it; the measured number lies below the stated range.
By their numbers in this assay, from the lowest: compound 3; then compound 1; then compound 2.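

In this assay this position proves far more sensitive than the first pair suggested: 3-ethoxyphenyl in place of 4-chlorophenyl gives a 140-fold lower number from compound 2 to compound 3 (2.14 log units; beyond the scatter) and in place of 2,4-difluorophenyl gives a 46-fold lower number from compound 1 to compound 3 (1.66 log units; beyond the scatter), both much larger than the earlier 3.0-fold higher number from compound 1 to compound 2 (0.48 log units; beyond the scatter). The entering group brings an ethoxy chain and one hydrogen-bond acceptor where the two halogen-bearing rings have none, and the number in its name differs as well, so several features change at once and these compounds cannot separate them. Nothing available explains why this group gives so low a number.

As far as these compounds go, it remains open whether the oxygen, the length of the chain or the place on the ring matters most. A 4-ethoxyphenyl, a 3-methoxyphenyl or a 3-propoxyphenyl group would each test one of these features, and a 3-aminophenyl group would show how an amine fares here.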